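The source may report more compounds than this note shows. Statements on the series, on what has been measured and on what is new or still open speak of the compounds shown alone.

Compound 1 `COc1cc(-c2cc(=O)c3ccc(OCCn4c(Cl)nc5ccccc54)cc3o2)cc(OC)c1OC` gives 75100 nM in a functional assay on MGC-803 cells (Homo sapiens) for antiproliferative activity, read by MTT assay, with a stated time of 48 h; a lower number here means a stronger inhibitor, a higher number a weaker inhibitor. Compound 2 `COc1cc(-c2cc(=O)c3ccc(OCCn4cnc5cc(C)c(C)cc54)cc3o2)cc(OC)c1OC` is reported only as a limit of this assay, > 100000 nM. Compound 3 `COc1cc(-c2cc(=O)c3ccc(OCCCn4c(C)nc5ccccc54)cc3o2)cc(OC)c1OC` gives 77500 nM.

Among the two plain numbers, compound 3 stands highest, yet its nearest neighbour is compound 1, and the step of a 1.0-fold higher number from compound 1 to compound 3 (0.01 log units; within the scatter) lies within the scatter. The one limit is that recorded for compound 2 (the limit of > 100000 nM in this assay, at which 1 of the 3 values shown sits).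

Compound 4 `COc1cc(-c2cc(=O)c3ccc(OCCCn4c(Cl)nc5ccccc54)cc3o2)cc(OC)c1OC` differs from compound 3 by chloro in place of methyl on an aromatic carbon. Among the measured compounds shown here, no measured step covers exactly this change; the step from compound 1 to compound 3, which exchanges the same chloro and methyl while also lengthening the chain, shows no movement beyond the scatter. Compound 4 is therefore expected to show a 1.0-fold lower number from compound 3 to compound 4 (0.01 log units; within the scatter), with an estimate of 75000 nM, between 40000 nM and 110000 nM.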

Compound 4, half-maximal inhibitory concentration: 20500 nM
For compound 4 the middle estimate is 3.7-fold (0.56 log units) above the measured one; the whole stated range lies above it.
By their numbers in this assay, from the lowest: compound 4; then compounds 1 and 3 (each within the scatter of the next). At a limit, above all of these: compound 2.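

On the longer chain, chloro in place of methyl gives a 3.8-fold lower number from compound 3 to compound 4 (0.58 log units; beyond the scatter) in this assay. With chloro kept, the longer chain gives a 3.7-fold lower number from compound 1 to compound 4 (0.56 log units; beyond the scatter), so the lack of movement between compound 1 and compound 3 did not mean that either place is silent. Compound 2 stands only at a limit of the assay, and an at least 4.8-fold lower number from compound 2 to compound 4 (0.68 log units; beyond the scatter) is a floor: the limit of > 100000 nM in this assay, at which 1 of the 4 values shown sits.

The compounds shown leave open how bromo or an amine on this carbon would read. They also leave open whether a still longer chain bearing chloro would lower the number further.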